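A few compounds are considered here, and "the series" means these few. Any claim that something is new, unique, unknown or untested is made for them only; others in the source may bear on it.

Of the compounds shown here, two have so far been tested in a functional assay on RXF 393 cells (Homo sapiens) for cytotoxicity, read by sulforhodamine B assay, with a stated time of 48 h, tested at 1 uM; on this read-out lower numbers stand for a stronger effect and higher numbers for a weaker effect at the one concentration tested. Compound 1 `COc1ccc(-c2cc(/C=C/C(=O)c3ccc(N)cc3)[nH]n2)cc1` gives a reading of 78% in this assay. Compound 2 `COc1cc(-c2cc(/C=C/C(=O)c3ccc(N)cc3)[nH]n2)cc(OC)c1OC` gives 67% in this assay. Among the measured compounds shown here, of the two numbers, compound 2 therefore stands lowest, which on this read-out means the stronger effect; its only neighbour, compound 1, lies higher by a margin that goes beyond the usual scatter of repeated measurements.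

Compound 3 `COc1ccc(C(=O)/C=C/c2cc(-c3cc(OC)c(OC)c(OC)c3)n[nH]2)cc1` has not yet been measured. It differs from compound 2 at one place: methoxy in place of amino on an aromatic carbon. For the measured compounds named here, no measured pair among the compounds in hand shows this same change, so the size of its effect cannot be read from any known step. Going by the values given here, the expected step of a number 6 percentage points higher from compound 2 to compound 3 (within the scatter) is small, in the direction of a slightly weaker effect, and may well lie within the scatter, the only anchor being the reading of compound 2 at 67%. Compound 3 is accordingly estimated to give 73%, with a range from 57% to 90%.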

Compound 3, a percentage reported as activity, at one concentration (the size of the read-out at that concentration, not a potency): 67%
For compound 3 the middle estimate is 6 percentage points above the measured one, within the range that was stated.
By their numbers in this assay, from the lowest: compounds 2 and 3 (each within the scatter of the next); then compound 1.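

In this assay, among the compounds shown here, replacing amino with methoxy on the aromatic carbon para to a large group gives no change at the digits printed from compound 2 to compound 3 (within the scatter), the first direct reading of this change at this position. The amino group carries a hydrogen-bond donor and methoxy carries none, so at this single concentration, and on the rest of the structure shared by these two compounds, the reading does not separate a group with that donor from one without it. Nothing available here explains why the two groups read alike.

This single step does not show whether other groups at the same position, such as hydroxyl, dimethylamino or a carboxylic acid, would also leave the reading in the same place, or whether a group would move it beyond the scatter. It also leaves open whether the same change from 4-aminophenyl to 4-methoxyphenyl would read alike on the core of compound 1, and whether the match between the two groups would hold at other concentrations.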